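The source may hold more compounds than are shown below. What is called first, only, known or untested is meant among the compounds shown, and "the series" means these compounds.

Measured so far in an assay on isolated protein for inhibition of DNA topoisomerase 1 (Homo sapiens), with a stated time of 30 min, tested at 100 uM; a lower number here means less inhibition, a higher number more inhibition at the concentration tested (going by the name of the read-out):
compound 1 `Cc1ccsc1-c1cc(-c2ccoc2)cc(-c2ccco2)n1`, giving 5.4%;
compound 2 `Clc1ccc(-c2cc(-c3ccoc3)cc(-c3ccccn3)n2)s1`, giving 3.1%;
compound 3 `Cc1ccsc1-c1cc(-c2ccc(Cl)o2)cc(-c2ccco2)n1`, giving 7.8%.

All three numbers are small and sit close together. Compound 3 is not separated from compound 1 or from compound 2 by more than the usual scatter, so nothing can be read into the order of the three. Going by the values given here, the single one-place step measured, a number 2.4 percentage points higher from compound 1 to compound 3 (within the scatter), stays within the scatter.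

Compound 4 `Cc1ccsc1-c1cc(-c2ccc(Cl)o2)cc(-c2cccnc2)n1` has not yet been measured. It differs from compound 3 in one place: pyridin-3-yl in place of furan-2-yl on an aromatic carbon.

Among the compounds with values here, no measured step swaps a furan ring for a pyridine ring at this place, so the only guidance is indirect. Within the data shown here, the one measured step, a number 2.4 percentage points higher from compound 1 to compound 3 (within the scatter), changed nothing beyond the scatter, and compound 2, which also carries a pyridine ring, gives 3.1%, no larger than the others. The expected step of a number 1.8 percentage points lower from compound 3 to compound 4 (within the scatter) is therefore none beyond the scatter. Compound 4 is estimated at 6%, with a range from 0% to 15%.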

Compound 4, a percentage reported as inhibition, at one concentration (the size of the read-out at that concentration, not a potency): 21.4%
Beside the measured number, compound 4's estimate is 15.4 percentage points below it; measured number above the stated range.
By their numbers in this assay, from the lowest: compounds 2, 1 and 3 (each within the scatter of the next); then compound 4.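

Swapping furan-2-yl for pyridin-3-yl on the aromatic carbon next to the ring nitrogen gives a number 13.6 percentage points higher from compound 3 to compound 4 (beyond the scatter) in this assay. Going by these compounds alone, this is the first one-place change here to lie beyond the scatter, so what sits at this position can alter the read-out, even though the size of the step is modest. The two groups count the same for hydrogen-bond donors and acceptors but differ in ring size and in their hetero atom, and no measurement available here shows what lies behind the rise.

On these data alone, it remains open whether the nitrogen of the new ring matters or whether a six-membered aromatic ring alone is enough, a question that a plain phenyl group or a pyridin-4-yl group at this place would address. It is also unclear whether the rise would persist with a different group in place of 5-chlorofuran-2-yl.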